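Methyl in place of nitro on compound 1

This account rests on a few compounds, and the source may have more. Where it says the series, first, only, none or still open, it means among the compounds named here.

In a functional assay on A549 cells (Homo sapiens) for antiproliferative activity, read by trypan blue exclusion, with a stated time of 24 h (a lower number here means a stronger inhibitor, a higher number a weaker inhibitor), compound 1 (`O=C1NC(=O)/C(=C/c2cn(Cc3ccc([N+](=O)[O-])cc3)c3ccccc23)N1`) gives > 40000 nM and this is a limit of the assay, not a number. Compound 1 therefore offers no exact starting point (the limit of > 40000 nM in this assay, at which 1 of the 3 values shown sits). Compound 2 (`O=C1NC(=O)/C(=C/c2cn(Cc3ccccc3)c3ccc(Cl)cc23)N1`) gives 29700 nM and compound 3 (`Cc1ccc2c(c1)c(/C=C1\NC(=O)NC1=O)cn2Cc1ccccc1`) gives 27700 nM in the same read-out. For the measured compounds named here, the one measured step is a 1.1-fold lower number from compound 2 to compound 3 (0.03 log units; within the scatter) and it stays within the scatter.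

Compound 4 (`Cc1ccc(Cn2cc(/C=C3\NC(=O)NC3=O)c3ccccc32)cc1`) is compound 1 with methyl in place of nitro on an aromatic carbon, para to a large group (methyl in place of nitro on an aromatic carbon). The measured step also brings in methyl, but at another place, so it bears on this change only indirectly. Compound 3 at 27700 nM sets the expected level. A further limit remains possible for compound 4. A small move toward a lower number is expected, with the estimated step being an at least 1.3-fold lower number from compound 1 to compound 4 (0.12 log units; that floor lies within the scatter) in this assay. For compound 4 the estimated value is 30000 nM (expected range 14000 nM to 55000 nM).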

Compound 4, half-maximal inhibitory concentration: 34800 nM
Compound 4: middle estimate off by 1.2-fold (0.06 log units), on the low side; the measured number falls inside the stated range.
By their numbers in this assay, from the lowest: compounds 3, 2 and 4 (each within the scatter of the next). At a limit, above all of these: compound 1.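

In this assay the change from 4-nitrophenyl to 4-methylphenyl reads as an at least 1.1-fold lower number from compound 1 to compound 4 (0.06 log units; that floor lies within the scatter). On these data alone, compound 1 stands at a limit of the assay, so only a floor can be read for this step, and its true size remains unknown: the limit of > 40000 nM in this assay, at which 1 of the 4 values shown sits. For the compounds shown here, compound 4 gives 34800 nM, which provides the first exact value with a group on this aromatic carbon, para to a large group, and a reference point that nitro could not supply.

As far as these compounds go, with one exact value at this position, no trend across groups can be drawn here, and the real gap between nitro and methyl stays open. From the compounds shown here alone, how an amine, a carboxylic acid or a longer alkyl chain would read at the same place is also open.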